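Adding one hydroxy group to compound 3

This account rests on a few compounds, and the source may have more. Where it says the series, first, only, none or still open, it means among the compounds named here.

Of the compounds shown here, three have been measured so far in an ADME assay on THP-1 cells (Homo sapiens) for cytotoxicity, read by WST assay, with a stated time of 24 h; on this read-out lower numbers stand for stronger inhibition and higher numbers for weaker inhibition. Compound 1 `CC1(C)C=Cc2c(O)cc(/C=C/c3ccc(O)cc3)cc2O1` gives > 10000 nM, which is a limit of the assay and not a number. Compound 2 `COc1ccc(/C=C/c2c(CC=C(C)C)c(O)cc3c2CC(O)C(C)(C)O3)cc1` gives 1800 nM and compound 3 `COc1ccc(/C=C/c2c(CC=C(C)C)c(O)cc(O)c2CC=C(C)C)cc1` gives 2700 nM, so these two values lie within the usual scatter of each other. Compound 4 `COc1ccc(/C=C/c2c(CC=C(C)C)c(O)cc(O)c2CC=C(C)C)cc1O` differs from compound 3 in one place: hydroxy in place of hydrogen on an aromatic carbon. The 4-methoxyphenyl thus becomes 3-hydroxy-4-methoxyphenyl. Among the compounds with values here, no measured pair shows this change, so no shift beyond the scatter is expected. The expected change, a 1.4-fold lower number from compound 3 to compound 4 (0.13 log units; within the scatter), is small, in the direction of stronger inhibition. For compound 4 the estimated value is 2000 nM, with an expected range from 700 nM to 6000 nM.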

Compound 4, half-maximal inhibitory concentration: 3900 nM
Compound 4: the middle estimate sits 2.0-fold (0.29 log units) below what was measured, within the range that was stated.
By their numbers in this assay, from the lowest: compounds 2, 3 and 4 (each within the scatter of the next, the first and the last beyond it). At a limit, above all of these: compound 1.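

In this assay, hydroxy on the aromatic carbon ortho to the methoxy group gives a 1.4-fold higher number from compound 3 to compound 4 (0.16 log units; within the scatter) and so shows no shift that can be told from the scatter. Compound 4 still reads as a measured number, so this hydroxy does not carry the read-out to the top of the assay's range. Only compound 1 stands at a limit, which is not a number: the limit of > 10000 nM in this assay, at which 1 of the 4 values shown sits.

Still open, from the compounds shown here alone, is whether a fluorine, an amine or a longer alkoxy chain on this same carbon would move the number beyond the scatter.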